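Swapping Ethyl for Cyano on the Amide Aryl Ring

This account rests on a few compounds, and the source may have more. Where it says the series, first, only, none or still open, it means among the compounds named here.

Three compounds sharing one core differ only in the aryl group attached to the amide carbonyl. In a functional assay on HeLa cells (Homo sapiens) for antiproliferative activity, read by CCK-8 assay, with a stated time of 72 h (on this read-out lower numbers stand for stronger inhibition and higher numbers for weaker inhibition), compound 1 `COc1ccccc1C(=O)Nc1cccc(-c2oc3cc(-c4ccc(F)cc4)ccc3c(=O)c2O)c1` gives 14100 nM, compound 2 `Cc1cccc(C(=O)Nc2cccc(-c3oc4cc(-c5ccc(F)cc5)ccc4c(=O)c3O)c2)c1` gives 6650 nM, and compound 3 `CCc1ccc(C(=O)Nc2cccc(-c3oc4cc(-c5ccc(F)cc5)ccc4c(=O)c3O)c2)cc1` gives 21000 nM. Compound 3 has the highest number of the three: the step of a 1.5-fold higher number from compound 1 to compound 3 (0.17 log units; within the scatter) lies within the scatter, while the step of a 3.2-fold higher number from compound 2 to compound 3 (0.50 log units; beyond the scatter) is beyond it, so compound 3 is clearly weaker than compound 2 but cannot be ordered against compound 1.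

Compound 4 `N#Cc1ccc(C(=O)Nc2cccc(-c3oc4cc(-c5ccc(F)cc5)ccc4c(=O)c3O)c2)cc1` is the next step from compound 3: cyano in place of ethyl on an aromatic carbon. For the measured compounds named here, none of the measured steps changes a group at this one place while holding everything else fixed; the steps of a 2.1-fold lower number from compound 1 to compound 2 (0.33 log units; beyond the scatter) and a 3.2-fold higher number from compound 2 to compound 3 (0.50 log units; beyond the scatter) each move the substituent to a different ring position as well as changing it, and both are only modest in size. There is thus no direct guide for replacing ethyl with cyano at a fixed position. Given that the three measured values differ only modestly, the expected step of a 1.4-fold lower number from compound 3 to compound 4 (0.15 log units; within the scatter) is small, with no clear direction beyond the scatter. Compound 4 is therefore estimated at 15000 nM, within a range from 6000 nM to 45000 nM.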

Compound 4, half-maximal inhibitory concentration: 23300 nM
The estimate for compound 4 lay 1.6-fold (0.19 log units) below the measured number, within the range that was stated.
By their numbers in this assay, from the lowest: compound 2; then compounds 1, 3 and 4 (each within the scatter of the next).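

For the compounds shown here, this is the first pair that exchanges one group at a fixed place, on the aromatic carbon para to a large group. In this assay, a 1.1-fold higher number from compound 3 to compound 4 (0.05 log units; within the scatter) shows that ethyl and cyano cannot be told apart there, even though cyano brings a hydrogen-bond acceptor that ethyl lacks. The wider comparison fits this: a 1.7-fold higher number from compound 1 to compound 4 (0.22 log units; within the scatter) also stays inside the usual variation, whereas a 3.5-fold higher number from compound 2 to compound 4 (0.54 log units; beyond the scatter) does not, so the 3-methylphenyl amide remains the only one of the four that stands clear of the others, with the lowest number. No measurement shown here offers an explanation for these results.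

The four compounds do not separate the effect of the substituent from that of its ring position, as none carries the same group at two different places on the ring. On these data alone, it also remains open whether an amine, a carboxylic acid or a chain longer than ethyl at the para place would shift the number beyond the usual variation.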